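A few compounds are considered here, and "the series" means these few. Any claim that something is new, unique, unknown or untested is made for them only; others in the source may bear on it.

Compound 1, `Cc1oc(-c2ccc(Cl)c(Cl)c2)nc1CN1CCC(C(=O)NCCCN2C[C@H](C)C[C@H](C)C2)CC1`: 3170 nM
Compound 2, `Cc1ccccc1-c1nc(CN2CCC(C(=O)NCCN3C[C@H](C)C[C@H](C)C3)CC2)c(C)o1`: 24400 nM

In an ADME assay on Huh7.5.1 cells (Homo sapiens) for cytotoxicity, read by ATP content, with a stated time of 48 h (on this read-out higher numbers stand for lower toxicity in this test and lower numbers for higher toxicity in this test), compound 1 gives 3170 nM, the lowest of the two numbers recorded. Compound 2 gives 24400 nM, a higher number that lies beyond the scatter of the test. For the measured compounds named here, compound 2 differs from compound 1 in more than one place, so no single step between them can be drawn; the two values show only that compound 2 sits well above compound 1.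

Compound 3, `COc1ccc(-c2nc(CN3CCC(C(=O)NCCCN4C[C@H](C)C[C@H](C)C4)CC3)c(C)o2)cc1OC`, has not yet been measured in this assay. It differs from compound 1 in one place: 3,4-dimethoxyphenyl in place of 3,4-dichlorophenyl on an aromatic carbon. Going by the values given here, no pair of measured compounds that differ in a single place exists, so the size of this change cannot be read from a measured step. On the two values at hand, compound 3 is expected to show a step of a 2.5-fold higher number from compound 1 to compound 3 (0.40 log units; beyond the scatter) upward from compound 1, of moderate size and likely beyond the scatter. Compound 3 is therefore estimated at 8000 nM, with a range from 2500 nM to 25000 nM.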

Compound 3, half-maximal cytotoxic concentration: 57200 nM
Estimate against measurement, compound 3: 7.2-fold (0.85 log units) below; measured number above the stated range.
By their numbers in this assay, from the lowest: compound 1; then compound 2; then compound 3.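

In this assay, for the compounds shown here, the step from 3,4-dichlorophenyl to 3,4-dimethoxyphenyl on an aromatic carbon of the five-membered aromatic ring is the first single change that can be read: an 18-fold higher number from compound 1 to compound 3 (1.26 log units; beyond the scatter). It shows that this position alone can move the read-out far beyond the scatter, in the direction of lower toxicity in this test, with the rest of the structure held constant. The entering group brings 2 hydrogen-bond acceptors where the leaving group has 0, but no measurement in hand connects that count or any other feature of the two groups to the size of the step.

Going by these compounds alone, with only this pair, it remains open whether both methoxy groups are needed for the step or whether a phenyl carrying a single methoxy group would give much of it. The compounds shown also leave open how a trifluoromethyl, a nitrile or an amine on the same phenyl ring would compare, and whether the step would carry over to other side chains on the shared core.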